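This account rests on a few compounds, and the source may have more. Where it says the series, first, only, none or still open, it means among the compounds named here.

Measured in an ADME assay on cells (Epithelial cell, Homo sapiens) for antiproliferative activity, read by MTT assay, with a stated time of 48 h; on this read-out lower numbers stand for stronger inhibition and higher numbers for weaker inhibition:
- compound 1 `CCOC(=O)/C(=C/c1ccccc1)CN1C(=O)[C@@H](OC)[C@H]1c1ccc(Cl)cc1`: "not toxic" (no number reported)
- compound 2 `COC(=O)/C(=C/c1ccccc1)CN1C(=O)[C@@H](OC)[C@H]1c1cccc(Cl)c1`: "not toxic" (no number reported)
- compound 3 `CO[C@@H]1C(=O)N(C/C(C#N)=C/c2ccccc2)[C@@H]1c1ccc(Cl)cc1Cl`: > 100000 nM

None of these three compounds has a single number in this assay. Compound 2 is reported only as "not toxic" (no number reported), and compound 1 carries the same wording, "not toxic" (no number reported). For compound 3, the entry > 100000 nM is a limit and not a number. For the measured compounds named here, compound 2 therefore stands without a measured potency, and no measured step connects it to either of the other two compounds.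

The next compound to be measured is compound 4 `COC(=O)/C(=C/c1ccccc1)CN1C(=O)[C@@H](OC)[C@H]1c1cccc(C(F)(F)F)c1`. The structural change is trifluoromethyl in place of chloro on an aromatic carbon of a six-membered aromatic ring of carbon only, meta to a large group, which reads as 3-chlorophenyl to 3-(trifluoromethyl)phenyl.

Going by the values given here, with no measured step to size this change, the expected step in this assay is none beyond the usual scatter, in either direction. This expectation rests on compound 2, reported as "not toxic" (no number reported). A report of a limit or of no toxicity is also the likely outcome here, with no number at all. The estimated value for compound 4 is 150000 nM, with an expected range from 50000 nM to 500000 nM.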

Compound 4, half-maximal inhibitory concentration: 71800 nM
The estimate for compound 4 lay 2.1-fold (0.32 log units) above the measured number; low and high end bracket the measured number.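

No step can be read from compound 2 to compound 4: in this assay, compound 4 gives 71800 nM, while compound 2 is reported as "not toxic" (no number reported). The compounds shown leave open the size of any change in antiproliferative activity between 3-chlorophenyl and 3-(trifluoromethyl)phenyl on the shared core.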